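Pyrazolyl enone series: aryl exchange on the carbonyl carbon

The source may hold more compounds than are shown below. What is called first, only, known or untested is meant among the compounds shown, and "the series" means these compounds.

For the measured compounds named here, compound 1 `COc1cc(-c2cc(/C=C/C(=O)c3ccc(N)cc3)[nH]n2)cc(OC)c1OC` gives 73200 nM in a functional assay on NCI-H23 cells (Homo sapiens) for inhibition, read by sulforhodamine B assay, with a stated time of 48 h (a higher number here means that more compound is tolerated, a lower number that less compound is tolerated), the highest of the two numbers measured so far. Compound 2 `COc1ccc(-c2cc(/C=C/C(=O)c3ccc(OC)c(OC)c3)[nH]n2)cc1` gives 34100 nM in this assay, a gap beyond the scatter. Compound 3 `COc1cc(-c2cc(/C=C/C(=O)c3ccc(Cl)c(Cl)c3)[nH]n2)cc(OC)c1OC` is not yet measured. It differs from compound 1 in one place: 3,4-dichlorophenyl in place of 4-aminophenyl on a carbonyl carbon. Going by the values given here, no measured pair shows this change. A modest fall in the number is expected, likely not far beyond the scatter, as the step from compound 1 to compound 3 is estimated at a 2.1-fold lower number from compound 1 to compound 3 (0.32 log units; beyond the scatter). For compound 3 the estimated value is 35000 nM, within 12000 nM to 100000 nM.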

Compound 3, concentration lethal to 50% of the cells: > 100000 nM
Compound 3: no number, only a limit; the forecaster's own chance of this, stated with the estimate: 10%; at least 2.8-fold (0.45 log units) between middle value and limit.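

Compound 3 gives > 100000 nM in this assay, which is a limit of the assay and not a number. At this position, 3,4-dichlorophenyl in place of 4-aminophenyl on a carbonyl carbon gives an at least 1.3-fold higher number from compound 1 to compound 3 (0.13 log units; that floor lies within the scatter), the first step read here, and it shows no fall in the number. The true size of the step cannot be read, because the reading ends at a limit: the limit of > 100000 nM in this assay, at which 1 of the 3 values shown sits.

Open, as far as these compounds go, is whether 4-chlorophenyl or 4-carboxyphenyl on the same core would read nearer compound 1 or compound 3. Also open, from the compounds shown here alone, is whether either chlorine alone accounts for the step.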